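The source may hold more compounds than are shown below. What is called first, only, known or untested is meant among the compounds shown, and "the series" means these compounds.

Compound 1 `O=C1C(O)=C(C(c2ccc([N+](=O)[O-])cc2)c2c[nH]c3ccccc23)C(=O)c2ccccc21`: in a toxicity assay (Homo sapiens) for cytotoxicity, read by MTT assay, with a stated time of 48 h (on this read-out lower numbers stand for stronger inhibition and higher numbers for weaker inhibition), compound 1 gives > 200000 nM, which is a limit of the assay and not a number.
Compound 2 `COc1cccc(C(C2=C(O)C(=O)c3ccccc3C2=O)c2c[nH]c3ccccc23)c1`: in this assay compound 2 gives 110000 nM.

Compound 2 holds the only number shown. The other value shown is a limit (the limit of > 200000 nM in this assay, at which 1 of the 2 values shown sits). Compound 3 `O=C1C(O)=C(C(c2cccc([N+](=O)[O-])c2)c2c[nH]c3ccccc23)C(=O)c2ccccc21` differs from compound 2 by nitro in place of methoxy on an aromatic carbon. For the measured compounds named here, the one measured step that bears on this is an at least 1.8-fold lower number from compound 1 to compound 2 (0.25 log units; that floor lies within the scatter), where a nitro-bearing ring gave way to a methoxy-bearing one and the change stayed within the scatter against a limit. With nitro entering here, the number is expected to move in the opposite direction by a 1.8-fold higher number from compound 2 to compound 3 (0.26 log units; within the scatter), possibly reaching the limit again. Compound 3 is therefore estimated at 200000 nM, range 90000 nM to 450000 nM.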

Compound 3, half-maximal inhibitory concentration: 91200 nM
The estimate for compound 3 lay 2.2-fold (0.34 log units) above the measured number, and the stated range covers the measured number.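

Nitro and methoxy on this aromatic carbon, meta to a large group, do not separate in this assay: the step reads a 1.2-fold lower number from compound 2 to compound 3 (0.08 log units; within the scatter). For the compounds shown here, the place of the nitro group on the ring gives the first step beyond the scatter, with 3-nitrophenyl in place of 4-nitrophenyl: an at least 2.1-fold lower number from compound 1 to compound 3 (0.34 log units; beyond the scatter). That step has a limit and not a number at its start, held by compound 1: the limit of > 200000 nM in this assay, at which 1 of the 3 values shown sits.

Open, on these data alone, is how an amine or a carboxylic acid on this aromatic carbon would read. Also open, as far as these compounds go, is whether 4-methoxyphenyl would differ from the 3-methoxyphenyl of compound 2 as the two nitrophenyl groups do.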